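Notes on replacing ethyl in compound 3

The compounds below may be only part of what the source reports. "The series", "measured", "known", "first", "only" and "open" are said of these compounds alone.

Measured values in a functional assay on KYSE-450 cells (Homo sapiens) for inhibition, read by CCK-8 assay, with a stated time of 48 h; on this read-out higher numbers stand for weaker inhibition and lower numbers for stronger inhibition:
- compound 1 `COc1ccc(CN(C(=O)CSC(=S)N2CCCC2)c2cc(OC)c(OC)c(OC)c2)cc1` gives 13800 nM
- compound 2 `COc1ccc(CN(C(=O)CSC(=S)N2CCc3ccccc32)c2cc(OC)c(OC)c(OC)c2)cc1` gives 6940 nM
- compound 3 `CCN1CCN(CC(=O)N(Cc2ccc(OC)cc2)c2cc(OC)c(OC)c(OC)c2)CC1` gives 16100 nM

Compound 3 stands at the upper end of the three numbers, together with compound 1. The step of a 1.2-fold higher number from compound 1 to compound 3 (0.07 log units; within the scatter) is small, while the step of a 2.3-fold higher number from compound 2 to compound 3 (0.37 log units; beyond the scatter) is modest.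

Compound 4 `COc1ccc(CN(C(=O)CN2CCN(C(=O)OC(C)(C)C)CC2)c2cc(OC)c(OC)c(OC)c2)cc1` carries tert-butoxycarbonyl in place of ethyl on an amine nitrogen in a ring, counted as tert-butoxycarbonyl in place of ethyl on an amine nitrogen in a ring, and the rest of compound 3 is kept.

Within the data shown here, no measured step changes this substituent directly. The closest evidence comes from exchanges of the whole group on the saturated chain carbon bound to a carbonyl carbon. Those exchanges moved the number little, as the step of a 1.2-fold higher number from compound 1 to compound 3 (0.07 log units; within the scatter) and the step of a 2.0-fold lower number from compound 1 to compound 2 (0.30 log units; within the scatter) show, and the largest was the step of a 2.3-fold higher number from compound 2 to compound 3 (0.37 log units; beyond the scatter) in the set. A step beyond the scatter is therefore not expected in this assay, in either direction. The expected change is a 1.3-fold lower number from compound 3 to compound 4 (0.13 log units; within the scatter) and would count as no real shift. For compound 4 the estimated value is 12000 nM, with an expected range from 5500 nM to 26000 nM.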

Compound 4, half-maximal inhibitory concentration: 8170 nM
Beside the measured number, compound 4's estimate is 1.5-fold (0.17 log units) above it, and the stated range covers the measured number.
By their numbers in this assay, from the lowest: compounds 2, 4, 1 and 3 (each within the scatter of the next, the first and the last beyond it).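

In this assay, the exchange at the amine nitrogen in the ring can now be read on its own, without the rest of the group changing: a 2.0-fold lower number from compound 3 to compound 4 (0.29 log units; within the scatter). The earlier compounds shown here showed only exchanges of the whole group on the saturated chain carbon, whereas this step shows that a swap confined to this nitrogen, from ethyl with no hydrogen-bond acceptors to tert-butoxycarbonyl with 2 hydrogen-bond acceptors, stays within the scatter in this assay. No measurement of any property of these two groups is at hand to interpret this outcome.

With only ethyl and tert-butoxycarbonyl shown on this nitrogen, no trend with the size or kind of substituent can be drawn, and it remains open how a hydrogen, an acetyl group, a benzyl group or a longer alkyl chain would read in this assay. Also open, from the compounds shown here alone, is whether tert-butoxycarbonyl would give a similar reading with other changes elsewhere on the shared core.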